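Adding a methoxy to compound 2: expected growth inhibition

The source may report more compounds than this note shows. Statements on the series, on what has been measured and on what is new or still open speak of the compounds shown alone.

Measured so far:
compound 1, `COc1cc(C2CC(c3cccc4ccccc34)=NN2C(C)=O)ccc1OCc1cn(Cc2ccc([N+](=O)[O-])cc2)nn1`: 95%
compound 2, `COc1ccc(C2CC(c3ccc(OCc4cn(Cc5ccc([N+](=O)[O-])cc5)nn4)cc3)=NN2C(C)=O)cc1`: 33%

In a functional assay on A549 cells (Homo sapiens) for inhibition, read by sulforhodamine B assay, tested at 100 uM (a lower number here means less inhibition of growth, a higher number more inhibition of growth at the concentration tested), compound 1 gives 95% and compound 2 gives 33%. Compound 2 stands lowest of the two numbers; compound 1 lies far higher, a gap beyond the usual scatter. The two compounds differ in more than one place, so nothing can be read from that gap about any single change.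

Compound 3, `COc1ccc(C2CC(c3ccc(OCc4cn(Cc5ccc([N+](=O)[O-])cc5)nn4)cc3)=NN2C(C)=O)cc1OC`, has not yet been measured. It differs from compound 2 in one place: methoxy in place of hydrogen on an aromatic carbon. For the measured compounds named here, no measured pair carries this same change, so there is no measured step to lean on.

In this assay the expected step is a number 7 percentage points higher from compound 2 to compound 3 (within the scatter), small and without a clear direction, most likely within the scatter. Compound 3 is expected to give 40%, with a range from 15% to 70%.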

Compound 3, percent growth inhibition at one concentration: 36%
Compound 3: the middle estimate sits 4 percentage points above what was measured; measured number inside the range.
By their numbers in this assay, from the lowest: compounds 2 and 3 (each within the scatter of the next); then compound 1.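

In this assay, for the compounds shown here, the change from 4-methoxyphenyl to 3,4-dimethoxyphenyl gives a number 3 percentage points higher from compound 2 to compound 3 (within the scatter) as the first step that can be read at a single place. On this one pair, a methoxy in place of hydrogen, ortho to a methoxy group and meta to a large group, leaves growth inhibition at the concentration tested within the scatter. Nothing available accounts for this result.

As far as these compounds go, whether an amine, a carboxylic acid or a longer chain at this same position would move the number beyond the scatter remains open. The steps from compound 1 to compound 2 and compound 3 cannot be read, as compound 1 differs from each in more than one place.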